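The compounds below may be only part of what the source reports. "The series", "measured", "known", "first", "only" and "open" are said of these compounds alone.

Three related compounds have been measured in an assay on IMR-32 cells with Neuronal acetylcholine receptor; alpha4/beta2 (Homo sapiens) as the target; a lower number here means a smaller maximal response, a higher number a larger maximal response. Compound 1 `Cc1ccncc1OC[C@@H]1CCCN1C` gives 12%, compound 2 `Cc1ccc(OC[C@@H]2CCCN2C)cn1` gives 30.9%, and compound 3 `CN1CCC[C@H]1COc1ccc(Cl)nc1` gives 17.9%. The step of a number 13 percentage points lower from compound 2 to compound 3 (beyond the scatter) lies beyond the scatter, while the numbers for compound 3 and compound 1 sit within the usual scatter of each other. The next compound, compound 4 `CN1CCC[C@H]1COc1ccc(Br)nc1`, differs from compound 3 in one place: bromo in place of chloro on an aromatic carbon. Within the data shown here, the only measured step bearing on this exchange at the same place is a number 13 percentage points lower from compound 2 to compound 3 (beyond the scatter), a modest shift. Swapping one halogen for another is expected to move the maximal response little, probably not beyond the scatter. Compound 4 is therefore estimated at 19%, with a range of 9% to 32%, meaning a number 1.1 percentage points higher from compound 3 to compound 4 (within the scatter).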

Compound 4, largest response reached (reported as maximum), in percent of the reference or control that the assay uses: 10.6%
Beside the measured number, compound 4's estimate is 8.4 percentage points above it, within the range that was stated.
By their numbers in this assay, from the lowest: compounds 4, 1 and 3 (each within the scatter of the next); then compound 2.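

On the aromatic carbon next to the ring nitrogen, bromo in place of chloro gives a number 7.3 percentage points lower from compound 3 to compound 4 (within the scatter) in this assay so these two halogens cannot be told apart here. Bromo in place of methyl gives a number 20.3 percentage points lower from compound 2 to compound 4 (beyond the scatter) so each halogen now has a step from methyl that lies beyond the scatter. No measurement shown here explains these differences. As far as these compounds go, it remains open whether a methoxy group, an amine or a nitrile at this place would give a maximal response nearer that of compound 2 or that of compound 4.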